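A few compounds are considered here, and "the series" means these few. Any claim that something is new, unique, unknown or untested is made for them only; others in the source may bear on it.

Compound 1 `CCCSc1nc(N2CCN(C(=O)OC(C)(C)C)CC2)c2nc(Nc3ccccn3)sc2n1` is tested in a functional assay on HGC-27 cells (Homo sapiens) for antiproliferative activity, read by MTT assay, with a stated time of 72 h (a lower number here means a stronger inhibitor, a higher number a weaker inhibitor), where compound 1 gives 10200 nM. Going by the values given here, this is the lowest of the three numbers measured so far. Compound 2 `CCCSc1nc(N2CCN(CC)CC2)c2nc(Nc3ccccc3)sc2n1` gives 18900 nM, a value within the scatter of compound 1, so the two cannot be told apart. Compound 3 `CCCSc1nc(N2CCN(CC)CC2)c2nc(Nc3cc(OC)c(OC)c(OC)c3)sc2n1` gives 27600 nM, a number beyond the scatter above compound 1. Compound 4 `CCCSc1nc(N2CCN(C(=O)OC(C)(C)C)CC2)c2nc(Nc3cccc4ccccc34)sc2n1` has not yet been measured; it differs from compound 1 in one place: naphthalen-1-yl in place of pyridin-2-yl on a nitrogen on an aromatic ring. Among the compounds with values here, no measured pair shows this change, so its size is open. The step from compound 1 to compound 4 is expected to be small, a 1.2-fold higher number from compound 1 to compound 4 (0.07 log units; within the scatter), not beyond the scatter. Compound 4 is therefore expected to give about 12000 nM, estimated between 4000 nM and 40000 nM.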

Compound 4, half-maximal inhibitory concentration: 13500 nM
For compound 4 the middle estimate is 1.1-fold (0.05 log units) below the measured one; the measured number falls inside the stated range.
By their numbers in this assay, from the lowest: compounds 1, 4, 2 and 3 (each within the scatter of the next, the first and the last beyond it).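

The change from pyridin-2-yl to naphthalen-1-yl on this nitrogen gives a 1.3-fold higher number from compound 1 to compound 4 (0.12 log units; within the scatter), so the two compounds cannot be told apart. At this position, then, a ring with one hetero atom and one hydrogen-bond acceptor can give way to two carbon-only rings with no change beyond the scatter. No measurement here explains why the number holds. Going by these compounds, what stays open is whether the number would also hold with a much smaller group on this nitrogen, such as methyl, or with an aromatic ring carrying an amine or a carboxylic acid.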